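A few compounds are considered here, and "the series" means these few. Any claim that something is new, unique, unknown or untested is made for them only; others in the source may bear on it.

In a functional assay on DU-145 cells (Homo sapiens) for cytotoxicity, read by MTT assay, with a stated time of 24 h (a lower number here means a stronger inhibitor, a higher number a weaker inhibitor), compound 1 (`CCCCCCCCCCCCCC(=O)Nc1nnc(S[C@@H]2O[C@H](COC(C)=O)[C@H](OC(C)=O)[C@H](OC(C)=O)[C@H]2OC(C)=O)s1`) gives 34700 nM and compound 3 (`C=CCCCCCCCCC(=O)Nc1nnc(S[C@@H]2O[C@H](COC(C)=O)[C@H](OC(C)=O)[C@H](OC(C)=O)[C@H]2OC(C)=O)s1`) gives 22900 nM on the same read-out. Going by the values given here, compound 2 (`CCCCCCCCCCCCCCCCCC(=O)Nc1nnc(S[C@@H]2O[C@H](CO)[C@H](O)[C@H](O)[C@H]2O)s1`) is recorded as "not active" (no number reported) with no number, so no step can be counted from it. Compound 4 (`CCCCCCCCCCCC(=O)Nc1nnc(S[C@@H]2O[C@H](CO)[C@H](O)[C@H](O)[C@H]2O)s1`) has yet to be measured, and it departs from compound 2 only in its chain. The change is hydrogen in place of hexyl on a saturated chain carbon, ten or more bonds along the chain from a carbonyl carbon and reads as hydrogen in place of hexyl on a saturated chain carbon, ten or more bonds along the chain from a carbonyl carbon. Among the compounds with values here, the only measured step is a 1.5-fold lower number from compound 1 to compound 3 (0.18 log units; within the scatter) for vinyl in place of pentyl, and it lies within the scatter. It bears on the present change only loosely: compound 1 and compound 3 carry ester groups that compound 2 and compound 4 lack. Taken alone, that step gives no reason to expect a large shift from a change of chain. Compound 2 with its "not active" (no number reported) result is the closest comparison, so a weak result or none at all is expected for compound 4. If this assay returns a number, the value estimated for compound 4 is 60000 nM within an expected range of 25000 nM to 150000 nM at this stage.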

Compound 4, half-maximal inhibitory concentration: "not active" (no number reported)
Nothing numeric was reported for compound 4, and the estimate cannot be compared.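

In this assay compound 2 and compound 4 are both recorded as "not active" with no number, so no step can be read between them. Nothing shown gives a measured explanation for this result. The compounds shown leave open whether chain length matters without the ester groups of compound 1 and compound 3, and whether those ester groups themselves matter.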